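The compounds below may be only part of what the source reports. "The series", "measured", "known", "first", "only" and "open" are said of these compounds alone.

Measured so far in an in vitro functional assay on cells for agonist activity at Bombesin receptor subtype-3 (Homo sapiens), read by luminescence and calcium flux; on this read-out higher numbers stand for an effect only at larger amounts of compound and lower numbers for an effect already at smaller amounts:

compound 1, `CCCCc1cnc(C(C)Cc2ccc(-c3ccccc3C(=O)O)cc2)[nH]1`: 2760 nM
compound 2, `O=C(O)c1ccccc1-c1ccc(CCc2ncc(Cc3ccccc3F)[nH]2)cc1`: 177 nM
compound 3, `CCCCc1cnc(C(Cc2ccc(-c3ccccc3C(=O)O)cc2)C(C)C)[nH]1`: 4620 nM

Compound 2 gives the lowest number of the three; compound 1 and compound 3 both lie well beyond the scatter above it. Among the compounds with values here, the only step between measured compounds that differ in one place is a 1.7-fold higher number from compound 1 to compound 3 (0.22 log units; within the scatter), which sits on the saturated chain carbon of the linker and not at the place now in question.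

Compound 4, `CC(C)CCc1cnc(CCc2ccc(-c3ccccc3C(=O)O)cc2)[nH]1`, is not yet measured. Its difference from compound 2: isobutyl in place of 2-fluorophenyl on a saturated chain carbon bound to an aromatic carbon. The same difference, cut one bond further out, reads 2-fluorobenzyl to isopentyl.

Within the data shown here, no measured step matches this change. What bears on it indirectly is that compound 1 and compound 3, which carry a plain alkyl chain (butyl) where compound 2 carries 2-fluorobenzyl, give numbers far above compound 2; compound 1, however, differs from compound 4 in more than one place, so their values can only be compared, not read as a step. On that basis the number is expected to rise clearly beyond the scatter, an 8.5-fold higher number from compound 2 to compound 4 (0.93 log units; beyond the scatter), though by how much is uncertain.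

Compound 4 is therefore estimated at 1500 nM in this assay, with a range of 400 nM to 6000 nM.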

Compound 4, half-maximal effective concentration: 119 nM
The estimate for compound 4 lay 13-fold (1.10 log units) above the measured number; measured number outside the range, below it.
By their numbers in this assay, from the lowest: compounds 4 and 2 (each within the scatter of the next); then compounds 1 and 3 (each within the scatter of the next).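

In this assay the exchange of 2-fluorophenyl for isobutyl on a saturated chain carbon bound to an aromatic carbon gives a 1.5-fold lower number from compound 2 to compound 4 (0.17 log units; within the scatter) and so does not separate the two groups. Within the data shown here, this is the first step that can be read at this place, and it shows that the 7 heavy atoms of 2-fluorophenyl, with its six-membered aromatic ring and its fluorine, can give way to the 4 carbons of isobutyl while the number stays within the scatter. For this pair, then, neither a ring nor fluorine at this place is required for a number in this range, and no measurement at hand gives a reason for the match between the two groups.

The compounds shown leave open how a longer chain such as hexyl, an unsubstituted phenyl or an amine would read at this place. They also leave open whether the exchange would read the same way on a core carrying methyl or isopropyl on the linker, as compound 1 and compound 3 do.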